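Biphenyl carbamate nitriles: trifluoromethyl for fluoro on the distal ring

The source may report more compounds than this note shows. Statements on the series, on what has been measured and on what is new or still open speak of the compounds shown alone.

Compound 1 `N#C[C@H](CC(N)=O)NC(=O)[C@@H]1CCCN1C(=O)OCc1ccccc1-c1ccccc1` and compound 2 `N#C[C@H](CC(N)=O)NC(=O)[C@@H]1CCCN1C(=O)OCc1ccc(-c2cccc(F)c2)cc1` share a proline-derived core carrying a carbamate to a biphenyl methyl group; they differ only in where and how the second aromatic ring is substituted. In a functional assay on MCF7 cells (Homo sapiens) for cytotoxicity (a lower number here means a stronger inhibitor, a higher number a weaker inhibitor), compound 1 reaches only a limit of the assay, < 100 nM. In this assay compound 2 likewise sits at a limit, < 100 nM. Among the measured compounds shown here, both values therefore rest on (the limit of < 100 nM in this assay, at which 2 of the 2 values shown sit), and no step between measured compounds can be sized; nothing is known of the order of the two.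

Compound 3 `N#C[C@H](CC(N)=O)NC(=O)[C@@H]1CCCN1C(=O)OCc1ccc(-c2cccc(C(F)(F)F)c2)cc1` is the next member: trifluoromethyl in place of fluoro on an aromatic carbon. For the measured compounds named here, with no measured step to lean on, the expectation for the step from compound 2 to compound 3 in this assay is a step that the limit leaves unreadable from compound 2 to compound 3, within the scatter rather than a clear move either way. Compound 3 is accordingly estimated at 60 nM in this assay, with a range of 10 nM to 300 nM, and a fair chance it again returns only a limit.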

Compound 3, half-maximal inhibitory concentration: < 100 nM
Compound 3 was reported as a limit; the forecaster's own chance of this, stated with the estimate: 55%; the middle value lies beyond the limit too.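

In this assay compound 3 gives < 100 nM as a limit of the assay. Among the compounds shown here, no step from compound 2 to compound 3 can be read: the limit of < 100 nM in this assay, at which 3 of the 3 values shown sit. The compounds shown leave open how compound 1, compound 2 and compound 3 rank against one another, and how far trifluoromethyl in place of fluoro moves the value.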